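The compounds below may be only part of what the source reports. "The series", "measured", "known", "first", "only" and "open" are said of these compounds alone.

Within the data shown here, compound 3, `CC(=O)OC[C@H]1O[C@H](OC[C@@H](Cn2cc(CN(c3nc(-c4ccc(Br)cc4)no3)C3CCCCC3)nn2)OC(C)=O)C=C[C@@H]1OC(C)=O`, gives 39.1 ug/mL in an ADME assay on RAW264.7 cells (Mus musculus) for cytotoxicity, read by MTT assay, with a stated time of 48 h (on this read-out lower numbers stand for higher toxicity in this test and higher numbers for lower toxicity in this test), and stands second highest among the three numbers measured so far. Its nearest neighbour is compound 2, `CC(=O)OC[C@H]1O[C@H](OC[C@@H](Cn2cc(CN(c3nc(-c4cccc(C)c4)no3)C3CCCCC3)nn2)OC(C)=O)C=C[C@@H]1OC(C)=O`, which in this assay gives 46.4 ug/mL; the furthest is compound 1, `CC(=O)OC[C@H]1O[C@H](OC[C@@H](Cn2cc(CN(c3nc(-c4ccc(F)cc4)no3)C3CCCCC3)nn2)OC(C)=O)C=C[C@@H]1OC(C)=O`, which gives 31.5 ug/mL. Every step among these three stays within the scatter: a 1.5-fold higher number from compound 1 to compound 2 (0.17 log units; within the scatter), a 1.2-fold higher number from compound 1 to compound 3 (0.09 log units; within the scatter) and a 1.2-fold lower number from compound 2 to compound 3 (0.07 log units; within the scatter). Compound 4, `CC(=O)OC[C@H]1O[C@H](OC[C@@H](Cn2cc(CN(c3nc(-c4ccccc4)no3)C3CCCCC3)nn2)OC(C)=O)C=C[C@@H]1OC(C)=O`, differs from compound 3 by hydrogen in place of bromo on an aromatic carbon. The earlier exchange of one halogen for another on an aromatic carbon, a 1.2-fold higher number from compound 1 to compound 3 (0.09 log units; within the scatter), bears most closely on this change and stayed within the scatter, as did the exchange of the whole aromatic group, a 1.2-fold lower number from compound 2 to compound 3 (0.07 log units; within the scatter). Removing the bromo is therefore expected to shift the number no further than the scatter, a 1.0-fold lower number from compound 3 to compound 4 (0.01 log units; within the scatter). Compound 4 is estimated at 38 ug/mL, within a range from 20 ug/mL to 72 ug/mL.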

Compound 4, half-maximal cytotoxic concentration: 28.6 ug/mL
Beside the measured number, compound 4's estimate is 1.3-fold (0.12 log units) above it; measured number inside the range.
By their numbers in this assay, from the lowest: compounds 4, 1, 3 and 2 (each within the scatter of the next).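

Removing the substituent altogether still leaves every step within the scatter: hydrogen in place of bromo gives (a 1.4-fold lower number from compound 3 to compound 4 (0.14 log units; within the scatter)), hydrogen in place of fluoro gives (a 1.1-fold lower number from compound 1 to compound 4 (0.04 log units; within the scatter)), and hydrogen in place of methyl gives (a 1.6-fold lower number from compound 2 to compound 4 (0.21 log units; within the scatter)). On this ring, then, the number does not depend measurably on having a bromo, fluoro or methyl group rather than hydrogen. No measurement shown here explains these small steps. The compounds shown carry only these small groups on the ring. As far as these compounds go, whether an amine or a carboxylic acid there would produce a step beyond the scatter remains open.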